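Working notes: from compound 3 to compound 4

The compounds below may be only part of what the source reports. "The series", "measured", "known", "first", "only" and "open" are said of these compounds alone.

Measured in a functional assay on HeLa cells (Homo sapiens) for cytotoxicity, read by MTT assay (on this read-out higher numbers stand for weaker inhibition and lower numbers for stronger inhibition), so far:
compound 1 `COCOc1cc(/C=C\c2cc(OC)c(OC)c(OC)c2)ccc1OC` gives 197 nM
compound 2 `COCOc1cc(C2CC2c2cc(OC)c(OC)c(OC)c2)ccc1OC` gives 24000 nM
compound 3 `COc1ccc(C2CC2c2cc(OC)c(OC)c(OC)c2)cc1OP(=O)(O)O` gives 370 nM

Compound 3 sits within the scatter of compound 1 and far from compound 2. Compound 4 `COc1ccc(C2CC2c2cc(OC)c(OC)c(OC)c2)cc1NC(=O)OC(C)(C)C` carries a group of 8 heavy atoms (5 carbon, 1 nitrogen, 2 oxygen; no ring) in place of a group of 5 heavy atoms (4 oxygen, 1 phosphorus; no ring), on an aromatic carbon, the entering (tert-butoxycarbonyl)amino group standing ortho to a methoxy group. Among the measured compounds shown here, one measured step bears on this, the large 65-fold lower number from compound 2 to compound 3 (1.81 log units; beyond the scatter) in this assay, which gained the phosphorus-bearing group that compound 4 gives up. For the measured compounds named here, no measured compound carries the entering group, so the guide is loose. Expected is a 22-fold higher number from compound 3 to compound 4 (1.33 log units; beyond the scatter), towards weaker inhibition and beyond the scatter. Estimated for compound 4 is 8000 nM in a range from 1200 nM to 40000 nM.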

Compound 4, half-maximal inhibitory concentration: 10100 nM
Compound 4: the middle estimate sits 1.3-fold (0.10 log units) below what was measured, within the range that was stated.
By their numbers in this assay, from the lowest: compounds 1 and 3 (each within the scatter of the next); then compound 4; then compound 2.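

In this assay, on this aromatic carbon, ortho to a methoxy group, (tert-butoxycarbonyl)amino gives a 27-fold higher number from compound 3 to compound 4 (1.44 log units; beyond the scatter) and so does not hold the level of the phosphorus-bearing group. Set against methoxymethoxy, the same group gives only a 2.4-fold lower number from compound 2 to compound 4 (0.38 log units; beyond the scatter) as a modest gain, so the large swing at this place is tied to the phosphorus-bearing group rather than to any replacement of methoxymethoxy.

As far as these compounds go, whether a free amine or a carboxylic acid here would sit nearer compound 3 or compound 4 stays open. No data at hand explain the gap between these groups.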